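The source may hold more compounds than are shown below. What is called first, only, known or untested is meant among the compounds shown, and "the series" means these compounds.

Compound 3 `Cc1ccc(OCc2cn(C(c3ccc(C#N)cc3)c3ccc(C#N)cc3)nn2)cc1` gives 11000 nM in an assay on isolated protein for inhibition of Aromatase (Homo sapiens), read by fluorescence and colorimetric assay, with a stated time of 30 min (on this read-out higher numbers stand for weaker inhibition and lower numbers for stronger inhibition), level with compound 2 `N#Cc1ccc(C(c2ccc(C#N)cc2)n2cc(COc3ccccc3)nn2)cc1` at 11000 nM; compound 1 `N#Cc1ccc(C(c2ccc(C#N)cc2)n2cc(C3CCCCC3)nn2)cc1` gives 19300 nM, and the two steps to compound 3 were a 1.8-fold lower number from compound 1 to compound 3 (0.24 log units; within the scatter) and no change at the digits printed from compound 2 to compound 3 (within the scatter). Compound 4 `COc1ccc(OCc2cn(C(c3ccc(C#N)cc3)c3ccc(C#N)cc3)nn2)cc1` differs from compound 3 by methoxy in place of methyl on an aromatic carbon. Among the compounds with values here, the only step that bears on this place is no change at the digits printed from compound 2 to compound 3 (within the scatter), where adding a methyl at the same aromatic carbon produced nothing beyond the scatter, and the two larger exchanges from compound 1 also stayed within it. The expected step of no change at the digits printed from compound 3 to compound 4 (within the scatter) is therefore none beyond the scatter. Compound 4 is estimated at 11000 nM, in the range 5000 nM to 25000 nM.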

Compound 4, half-maximal inhibitory concentration: 12200 nM
Beside the measured number, compound 4's estimate is 1.1-fold (0.04 log units) below it; the measured number falls inside the stated range.
By their numbers in this assay, from the lowest: compounds 2, 3, 4 and 1 (each within the scatter of the next).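

Methoxy at this aromatic carbon, para to a large group, gives a result no different from methyl (a 1.1-fold higher number from compound 3 to compound 4 (0.04 log units; within the scatter)) or from hydrogen (a 1.1-fold higher number from compound 2 to compound 4 (0.04 log units; within the scatter)). Within the data shown here, the exchange from cyclohexyl also stays within the scatter (a 1.6-fold lower number from compound 1 to compound 4 (0.20 log units; within the scatter)), so the oxygen of methoxy adds nothing that this read-out can separate from the earlier compounds. No measurement shown offers an explanation for this flat result.

As far as these compounds go, it remains open whether an amine or a carboxylic acid at this carbon, or a longer chain in place of methoxy, would move the number beyond the scatter.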